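Notes on the step from compound 3 to compound 4

This account rests on a few compounds, and the source may have more. Where it says the series, first, only, none or still open, it means among the compounds named here.

Three compounds of the shared core carry measurements in an assay on HEK293 cells for inhibition of cytochrome P450 1A1 (Homo sapiens), read by fluorescence, with stated times of 30 min and 60 min; a lower number here means a stronger inhibitor, a higher number a weaker inhibitor. Compound 1 `COc1ccc(/C=C/C(=O)c2ccncc2)cc1OC` gives 420 nM. Compound 3 `COc1cc(/C=C/C(=O)c2ccncc2)cc(OC)c1OC` gives 58 nM, the lowest of the three numbers. Compound 2 `CCOc1cc(/C=C/C(=O)c2ccncc2)cc(OC)c1OCC` gives 65 nM, and the values of compound 2 and compound 3 lie within the scatter of each other, so no order between them is claimed. Going by the values given here, the single step recorded between compounds that differ in one place is a 7.2-fold lower number from compound 1 to compound 3 (0.86 log units; beyond the scatter), methoxy in place of hydrogen on an aromatic carbon.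

Compound 4 `CCOc1cc(/C=C/C(=O)c2ccncc2)cc(OC)c1OC` is not yet measured. It differs from compound 3 by methyl in place of hydrogen on a saturated chain carbon bound to an oxygen on an aromatic ring. The recorded step from compound 1 to compound 3 concerns a different kind of change and does not bear on this one. Among the compounds with values here, no step is counted between compound 2 and compound 3, but their two values show that a compound with two ethoxy groups where compound 3 carries methoxy sits within the scatter of compound 3. Compound 4 carries a single ethoxy. The step expected here is a 1.0-fold higher number from compound 3 to compound 4 (0.01 log units; within the scatter), none beyond the scatter. Compound 4 is therefore estimated at 60 nM, with a range from 30 nM to 120 nM.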

Compound 4, half-maximal inhibitory concentration: 63 nM
For compound 4 the middle estimate is 1.1-fold (0.02 log units) below the measured one; low and high end bracket the measured number.
By their numbers in this assay, from the lowest: compounds 3, 4 and 2 (each within the scatter of the next); then compound 1.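

In this assay, methyl in place of hydrogen on a saturated chain carbon bound to an oxygen on an aromatic ring gives a 1.1-fold higher number from compound 3 to compound 4 (0.04 log units; within the scatter) as a single change, so methoxy to ethoxy at this place can now be read directly rather than inferred from a compound with two ethoxy groups. The same change read from the two-ethoxy side, hydrogen in place of methyl, gives a 1.0-fold lower number from compound 2 to compound 4 (0.01 log units; within the scatter) and is also within the scatter, so at this place neither one ethoxy nor two separates from the others in this set. The remaining new step is a 6.7-fold lower number from compound 1 to compound 4 (0.82 log units; beyond the scatter) and thus lies beyond the scatter, showing that ethoxy, like methoxy in the earlier step, goes with a lower number than hydrogen on an aromatic carbon.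

From the compounds shown here alone, whether a longer chain such as propoxy, or a branched isopropoxy, would stay within the scatter at this place remains open, as does the effect of replacing the ether oxygen with an amine. No supporting evidence is available to explain these numbers.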